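This account rests on a few compounds, and the source may have more. Where it says the series, first, only, none or still open, it means among the compounds named here.

In a functional assay on ECa-109 cells for inhibition, with ECa-109 cell line (Homo sapiens) as the target, read by sulforhodamine B assay (on this read-out lower numbers stand for stronger inhibition and higher numbers for weaker inhibition), compound 3 `CCCN(CCC)C1=CC(=O)c2nc3n(c2C1=O)[C@H]1OC[C@@H](O)[C@H]1OC3` gives > 16000 nM as a limit of the assay and not a number. Going by the values given here, it is the only compound of this set so placed (the limit of > 16000 nM in this assay, at which 1 of the 3 values shown sits). Compound 1 `CCc1ccc(NC2=CC(=O)c3nc4n(c3C2=O)[C@H]2OC[C@@H](O)[C@H]2OC4)cc1` reads 3080 nM and compound 2 `CCOc1ccc(NC2=CC(=O)c3nc4n(c3C2=O)[C@H]2OC[C@@H](O)[C@H]2OC4)cc1` reads 3210 nM on the same read-out. Between these two lies a 1.0-fold higher number from compound 1 to compound 2 (0.02 log units; within the scatter) with ethoxy in place of ethyl on an aromatic carbon.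

Compound 4 `O=C1C=C(Nc2ccccc2)C(=O)c2c1nc1n2[C@H]2OC[C@@H](O)[C@H]2OC1` is still unmeasured. Its difference from compound 3 is anilino in place of dipropylamino on a double-bonded ring carbon. The closest measured step is an at least 5.1-fold higher number from compound 1 to compound 3 (0.71 log units; beyond the scatter) with dipropylamino in place of (4-ethylphenyl)amino on a double-bonded ring carbon, which is nearly the same exchange run the other way. From that step, a move of at least modest size toward a lower number is expected in this assay on going to compound 4. Among the compounds with values here, no measured compound carries the plain anilino, so the range stays wide. The expected change on this estimate is an at least 4.0-fold lower number from compound 3 to compound 4 (0.60 log units; beyond the scatter) and it rests on a limit at one end. For compound 4 the estimate is 4000 nM with an expected range from 1700 nM to 9500 nM on this read-out.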

Compound 4, half-maximal inhibitory concentration: 4970 nM
The estimate for compound 4 lay 1.2-fold (0.09 log units) below the measured number; the measured number falls inside the stated range.
By their numbers in this assay, from the lowest: compounds 1, 2 and 4 (each within the scatter of the next). At a limit, above all of these: compound 3.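

In this assay, an at least 3.2-fold lower number from compound 3 to compound 4 (0.50 log units; beyond the scatter) shows that the plain anilino on the double-bonded ring carbon is enough to separate this series from the dipropylamino compound, so the earlier contrast does not depend on a substituent on the aromatic ring. Neither ethyl nor ethoxy is needed on that aromatic carbon, with a 1.6-fold higher number from compound 1 to compound 4 (0.21 log units; within the scatter) and a 1.5-fold higher number from compound 2 to compound 4 (0.19 log units; within the scatter), so hydrogen, ethyl and ethoxy cannot be told apart at this position in the compounds shown. The value of compound 3 is a limit of the assay and not a number, which leaves the anilino-for-dipropylamino change a bound and not a measured size: the limit of > 16000 nM in this assay, at which 1 of the 4 values shown sits.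

The compounds shown leave open whether the loss belongs to alkylamino groups in general or to dipropylamino alone, a question that dimethylamino or a cyclic amine such as morpholine would address, as would an anilino carrying a methyl group on its nitrogen for the role of the anilino hydrogen. As far as these compounds go, on the aromatic ring, it also remains open whether a group unlike ethyl and ethoxy, such as a carboxylic acid or a chlorine, would stay within the scatter of these values.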